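The source may hold more compounds than are shown below. What is called first, only, known or untested is meant among the compounds shown, and "the series" means these compounds.

Measured compounds in the series:

Compound 1, `O=C(CCCl)Nc1ccc(SCC(=O)Nc2cc(Cl)ccn2)cc1`: 21700 nM in a functional assay on HeLa cells (Homo sapiens) for antiproliferative activity, read by MTT assay, with a stated time of 48 h; a higher number here means a weaker inhibitor, a lower number a stronger inhibitor
Compound 2, `CC(C)(C)C(=O)Nc1ccc(SCC(=O)Nc2cc(Cl)ccn2)cc1`: in this assay compound 2 gives only a limit, > 80000 nM

Compound 2 is thus the weaker of the two measured entries: its value is a limit of the assay rather than a number, and it sits at the limit of > 80000 nM in this assay, at which 1 of the 2 values shown sits. Within the data shown here, the only measured step, an at least 3.6-fold higher number from compound 1 to compound 2 (0.56 log units; beyond the scatter), shows that exchanging the group on the carbonyl carbon of the amide shifts the read-out beyond the scatter, with the tert-butyl analogue at the limit.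

Compound 3, `C=CC(=O)Nc1ccc(SCC(=O)Nc2cc(Cl)ccn2)cc1`, differs from compound 2 by vinyl in place of tert-butyl on a carbonyl carbon. Among the measured compounds shown here, this reverses the direction of the one measured step: the tert-butyl that took compound 2 to the limit is removed and a smaller, unsaturated group is placed on the same carbonyl carbon. Because an at least 3.6-fold higher number from compound 1 to compound 2 (0.56 log units; beyond the scatter) shows the tert-butyl analogue as the weakest, the step back to a small acyl group is expected to lower the number in this assay, into the range where compound 1 stands or somewhat beyond it.

For compound 3 the expected result in this assay is 12000 nM, with a range of 2500 nM to 60000 nM; the expected step is an at least 6.6-fold lower number from compound 2 to compound 3 (0.82 log units; beyond the scatter).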

Compound 3, half-maximal inhibitory concentration: 25200 nM
Estimate against measurement, compound 3: 2.1-fold (0.32 log units) below; the range from low to high includes it.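

In this assay, vinyl in place of tert-butyl on a carbonyl carbon gives an at least 3.1-fold lower number from compound 2 to compound 3 (0.50 log units; beyond the scatter), so the earlier loss can be undone at this position by a change of this one group, though the size of the step rests on a limit. The entry for compound 2 is a limit of the assay and not a number, and it remains the only such entry in the series: the limit of > 80000 nM in this assay, at which 1 of the 3 values shown sits. Vinyl in place of 2-chloroethyl gives a 1.2-fold higher number from compound 1 to compound 3 (0.06 log units; within the scatter), so these two groups on the carbonyl carbon read alike, and the double bond of the vinyl group and the chlorine of the 2-chloroethyl group cannot be told apart in this read-out.

The compounds shown leave open whether any group at this position can bring the number clearly under the level shared by compound 1 and compound 3. A plain methyl or ethyl group on the same carbonyl carbon, or a chain ending in an amine, would show whether that level needs a double bond or a chlorine at all.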